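Butoxy in Place of Hydrogen: Outlook for Compound 4

The source may hold more compounds than are shown below. What is called first, only, known or untested is meant among the compounds shown, and "the series" means these compounds.

Compound 1 `O/N=C(/Nc1ccccc1)c1ccc2occc2c1` stands only at a limit on the numbers shown: in an assay on isolated protein for inhibition of Indoleamine 2,3-dioxygenase 1 (Homo sapiens), read by spectrophotometry (on this read-out lower numbers stand for stronger inhibition and higher numbers for weaker inhibition), compound 1 gives > 30000 nM, a limit of the assay and not a number. Compound 2 `O/N=C(/Nc1ccc(Cl)cc1)c1ccc2occc2c1` gives > 30000 nM in this assay, likewise a limit. Compound 3 `Cc1ccc(N/C(=N/O)c2ccc3occc3c2)cc1C` gives > 30000 nM, again a limit. For the measured compounds named here, the single one-place step, a step that the two limits leave unreadable from compound 1 to compound 2, is therefore unreadable, and all three values sit on (the limit of > 30000 nM in this assay, at which 3 of the 3 values shown sit). Compound 4 `CCCCOc1cccc(N/C(=N/O)c2ccc3occc3c2)c1` differs from compound 1 by butoxy in place of hydrogen on an aromatic carbon. Going by the values given here, no measured step involves a butoxy group, and none is readable at all, so in this assay no step beyond the scatter can be expected. Compound 4 is expected to remain at the limit, with an estimate of 40000 nM and a range from 10000 nM to 150000 nM. The expected step is a step that the limit leaves unreadable from compound 1 to compound 4.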

Compound 4, half-maximal inhibitory concentration: > 30000 nM
Compound 4: only a limit was reported; the forecaster's own chance of this, stated with the estimate: 80%; the middle value lies beyond the limit too.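

No new step can be read between compound 1 and compound 4, as both values are limits of the assay: the limit of > 30000 nM in this assay, at which 4 of the 4 values shown sit. The compounds shown leave open which change to the shared core, if any, would give a readable value.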